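A Tetrazole Gives Way to a Saturated Bicyclic Group

A few compounds are considered here, and "the series" means these few. Any claim that something is new, unique, unknown or untested is made for them only; others in the source may bear on it.

Of the compounds shown here, three sharing one core have been measured in an assay on cell membranes for binding affinity to adenosine receptor A1 (Cavia porcellus), read by radioligand binding; on this read-out higher numbers stand for weaker inhibition and lower numbers for stronger inhibition. Compound 1 `CCCn1c(=O)c2nc(C(O)(CC)CC)[nH]c2n(CCC)c1=O` gives 170 nM. Compound 2 `CCCn1c(=O)c2nc([C@@H]3CC4C=CC3C4)[nH]c2n(CCC)c1=O` gives 4.3 nM. For compound 3 `CCCn1c(=O)c2nc(-c3nn[nH]n3)[nH]c2n(CCC)c1=O` the assay reports only a limit, > 10000 nM, so compound 3 stands at the weak end of the three, as noted in the limit of > 10000 nM in this assay, at which 1 of the 3 values shown sits.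

Compound 4 `CCCn1c(=O)c2nc([C@@H]3CC4CCC3C4)[nH]c2n(CCC)c1=O` is the next compound to be measured. Its change from compound 3 is a group of 7 heavy atoms (7 carbon; 2 five-membered non-aromatic rings of carbon only) in place of a group of 5 heavy atoms (1 carbon, 4 nitrogen; one five-membered aromatic ring with 4 hetero atoms), on an aromatic carbon. The group entering is the saturated counterpart of the group carried by compound 2, and the measured steps bear on it directly: an at least 2300-fold higher number from compound 2 to compound 3 (3.36 log units; beyond the scatter) and an at least 58-fold higher number from compound 1 to compound 3 (1.76 log units; beyond the scatter), both large, run toward the tetrazole, while a 40-fold lower number from compound 1 to compound 2 (1.60 log units; beyond the scatter) runs toward the bicyclic group. Reversing the tetrazole for the bicyclic hydrocarbon should therefore give a large step downward in this assay, well beyond the scatter, roughly undoing the step from compound 2 to compound 3.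

Compound 4 is accordingly expected to land near compound 2, an estimated at least 1600-fold lower number from compound 3 to compound 4 (3.22 log units; beyond the scatter). The expected value for compound 4 is 6 nM, within a range from 2 nM to 25 nM.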

Compound 4, inhibition constant: 3.8 nM
The estimate for compound 4 lay 1.6-fold (0.20 log units) above the measured number; the range from low to high includes it.
By their numbers in this assay, from the lowest: compounds 4 and 2 (each within the scatter of the next); then compound 1. At a limit, above all of these: compound 3.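

In this assay, the saturated bicyclic group and the unsaturated group of compound 2 cannot be told apart at this position on the aromatic carbon (a 1.1-fold lower number from compound 2 to compound 4 (0.05 log units; within the scatter)), so the gain seen earlier with compound 2 does not depend on the unsaturation of that group. The saturated group also stands well clear of the other two groups: replacing 1-ethyl-1-hydroxypropyl gives a large step (a 45-fold lower number from compound 1 to compound 4 (1.65 log units; beyond the scatter)), and replacing 2H-tetrazol-5-yl gives a larger one still (an at least 2600-fold lower number from compound 3 to compound 4 (3.42 log units; beyond the scatter)), so an all-carbon group with no hydrogen-bond donors or acceptors is now seen twice to go with the low numbers in this series. The last of these steps starts from a limit and not from a number, which is all that is recorded for compound 3: (the limit of > 10000 nM in this assay, at which 1 of the 4 values shown sits).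

What the compounds shown leave open is whether an amine or a carboxylic acid attached to the saturated bicyclic group would keep a number close to that of compound 4 in this assay. Also open, on these data alone, is how a simple cyclopentyl ring at the same place would compare, and how the opposite configuration at the defined stereocentre of the bicyclic group would read.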